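The source may hold more compounds than are shown below. What is called first, only, known or untested is meant among the compounds shown, and "the series" means these compounds.

Measured compounds in a functional assay on KM12 cells (Homo sapiens) for antiproliferative activity; on this read-out higher numbers stand for weaker inhibition of growth and lower numbers for stronger inhibition of growth:
- compound 1, `CC(=O)Nc1ccc(S(=O)(=O)NNC(=O)c2cccnc2Nc2ccc(Cl)cc2)cc1`, gives > 100000 nM
- compound 2, `O=C(NNS(=O)(=O)c1ccc(F)cc1)c1cccnc1Nc1ccc(Cl)cc1Cl`, gives 49000 nM

Compound 1 stands at the top of the numbers shown: its value is a limit of this assay, not a measured number, as the limit of > 100000 nM in this assay, at which 1 of the 2 values shown sits, states. Going by the values given here, compound 2 is the only one of the pair with a definite figure, and it sits in the weak range of this assay. Among the compounds with values here, the two compounds differ at more than one place, so no single step between them can be read.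

Compound 3 is `O=C(NNS(=O)(=O)c1ccc(Cl)cc1Cl)c1cccnc1Nc1ccc(Cl)cc1` and is still to be measured in this assay. It is made from compound 1 by 2,4-dichlorophenyl in place of 4-acetamidophenyl on a sulfonyl sulfur; the rest of the shared core is unchanged. Within the data shown here, with no measured step of this kind available, the direction is open. An estimated value for compound 3 of 30000 nM, within 5000 nM to 100000 nM, is taken here. The expected step from compound 1 to compound 3 is thus an at least 3.3-fold lower number from compound 1 to compound 3 (0.52 log units; beyond the scatter), a move toward stronger inhibition of growth, though a value at the limit again remains a real possibility.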

Compound 3, concentration for total growth inhibition: 28800 nM
Beside the measured number, compound 3's estimate is 1.0-fold (0.02 log units) above it; the range from low to high includes it.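

Going by these compounds alone, at the sulfonyl sulfur, whose other neighbour is the sulfonamide nitrogen, 2,4-dichlorophenyl in place of 4-acetamidophenyl gives the first step that can be read, an at least 3.4-fold lower number from compound 1 to compound 3 (0.54 log units; beyond the scatter), a move toward stronger inhibition of growth in this assay. The group on the sulfonyl sulfur therefore matters to this read-out, although compound 3 at 28800 nM still lies in the weak range of this assay. The value of compound 1 is a limit of the assay and not a number, so the step has a bound on its size and no definite size: the limit of > 100000 nM in this assay, at which 1 of the 3 values shown sits.

The change removes the hydrogen-bond donor and acceptor of 4-acetamidophenyl and brings in two chlorine atoms in one move, so the compounds shown do not tell which part of the change carries the step, or how large the step really is. Open as well is how the read-out would respond at this place to an unsubstituted phenyl, a 4-aminophenyl or a phenyl bearing a carboxylic acid, any of which would help separate loss of the acetamide from entry of the chlorines.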